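The source may report more compounds than this note shows. Statements on the series, on what has been measured and on what is new or still open speak of the compounds shown alone.

Measured in an ADME assay on J774 cells (Mus musculus) for antiproliferative activity, with a stated time of 72 h; a lower number here means that less compound is needed, a higher number that more compound is needed for the effect:
- compound 1 `CCCCc1cc2c(=O)cc(C)[nH]c2cc1OCCOc1ccccc1`: 28000 nM
- compound 2 `CCCCc1cc2c(=O)c(-c3ccc(C(F)(F)F)cc3)c(C)[nH]c2cc1OCCOc1ccccc1`: 20000 nM
- compound 3 `CCCCc1cc2c(=O)c(-c3ccc(C(F)(F)F)cc3C)c(C)[nH]c2cc1OCCOc1ccccc1`: 20000 nM

Compound 3 stands level with compound 2, and all three values lie within the scatter of each other. Compound 4 `CCCCc1cc2c(=O)c(-c3c(C)noc3C)c(C)[nH]c2cc1OCCOc1ccccc1` carries 3,5-dimethyl-1,2-oxazol-4-yl in place of 2-methyl-4-(trifluoromethyl)phenyl on an aromatic carbon. Within the data shown here, no measured step covers this exchange directly. The nearest evidence is the introduction of the substituent at this carbon, with a 1.4-fold lower number from compound 1 to compound 2 (0.15 log units; within the scatter) and a 1.4-fold lower number from compound 1 to compound 3 (0.15 log units; within the scatter), and the added methyl, with no change at the digits printed from compound 2 to compound 3 (within the scatter). On these steps, no change beyond the scatter is expected in this assay. The estimate means a 1.1-fold higher number from compound 3 to compound 4 (0.04 log units; within the scatter). Compound 4 is expected at 22000 nM, with an estimated range of 12000 nM to 40000 nM.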

Compound 4, half-maximal effective concentration: 22000 nM
Compound 4: the middle estimate sits on the measured number at the digits printed; the range from low to high includes it.
By their numbers in this assay, from the lowest: compounds 2, 3, 4 and 1 (each within the scatter of the next).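

In this assay, 3,5-dimethyl-1,2-oxazol-4-yl at this aromatic carbon gives a 1.1-fold higher number from compound 3 to compound 4 (0.04 log units; within the scatter) and a 1.1-fold higher number from compound 2 to compound 4 (0.04 log units; within the scatter), so a five-membered aromatic ring with 2 hetero atoms and 2 hydrogen-bond acceptors reads the same as the two phenyl groups carrying trifluoromethyl. Against hydrogen at this carbon the step is a 1.3-fold lower number from compound 1 to compound 4 (0.10 log units; within the scatter), so all three groups shown now stay within the scatter of hydrogen. Nothing measured here accounts for this flat reading. Still open, going by these compounds, is whether a group of another kind at this carbon, such as an amine or a carboxylic acid, would move the number beyond the scatter.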